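Sulfonamide to acetamide on the benzoxazole core: an oral exposure estimate

A few compounds are considered here, and "the series" means these few. Any claim that something is new, unique, unknown or untested is made for them only; others in the source may bear on it.

Compound 1 `C[C@H](c1ccc(-c2cc(Cl)ccc2-c2nc(=O)o[nH]2)cc1)N(CC1CC1)c1nc2c(C(=O)O)cccc2o1`: 1300 ng.h/mL
Compound 3 `CCCCN(c1nc2c(C(=O)O)cccc2o1)[C@H](C)c1ccc(-c2cc(Cl)ccc2-c2nc(=O)o[nH]2)cc1`: 1040 ng.h/mL
Compound 2 `CCCCN(c1nc2c(NS(C)(=O)=O)cccc2o1)[C@H](C)c1ccc(-c2ccccc2-c2nnn[nH]2)cc1`: 73.8 ng.h/mL

In an ADME assay on the whole organism (Macaca fascicularis) for pharmacokinetics, read by LC-MS, using cassette dosing, at a dose of 1 mg/kg by the oral route (a lower number here means less compound in the circulation, a higher number more compound in the circulation at the dose given), compound 2 gives 73.8 ng.h/mL, the lowest of the three numbers; compound 3 gives 1040 ng.h/mL and compound 1 gives 1300 ng.h/mL, both well above it. Compound 4 `CCCCN(c1nc2c(NC(C)=O)cccc2o1)[C@H](C)c1ccc(-c2ccccc2-c2nnn[nH]2)cc1` differs from compound 2 by acetyl in place of methylsulfonyl on a nitrogen on an aromatic ring. For the measured compounds named here, the only measured step, a 1.3-fold lower number from compound 1 to compound 3 (0.10 log units; within the scatter), concerns a different position and a different core, so no measured step bears on this change. With nothing to point either way, compound 4 is expected to stay near compound 2, with a 1.2-fold higher number from compound 2 to compound 4 (0.09 log units; within the scatter) as the expected step. Compound 4 is therefore estimated at 90 ng.h/mL, in the range 25 ng.h/mL to 320 ng.h/mL.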

Compound 4, area under the concentration-time curve: 41.6 ng.h/mL
Estimate against measurement, compound 4: 2.2-fold (0.34 log units) above, within the range that was stated.
By their numbers in this assay, from the lowest: compounds 4 and 2 (each within the scatter of the next); then compounds 3 and 1 (each within the scatter of the next).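

In this assay, for the compounds shown here, acetyl in place of methylsulfonyl on a nitrogen on an aromatic ring gives a 1.8-fold lower number from compound 2 to compound 4 (0.25 log units; within the scatter), the first measured step at this position. Methanesulfonamido and acetamido therefore cannot be told apart by oral exposure on this background, although acetyl has one heavy atom fewer and one hydrogen-bond acceptor fewer. Nothing available accounts for the exposure of either compound. Still open, on these data alone, is how a free amine or a longer acyl chain, such as propanoyl, would read on this nitrogen. Whether the step holds on another background is also unknown.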